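The source may hold more compounds than are shown below. What is called first, only, known or untested is meant among the compounds shown, and "the series" means these compounds.

Compound 1 `CCCCC/C=C\C[C@]1(O)C=CC(=O)/C1=C/C=C/CCCC(=O)OC` is the only one of the three measured compounds to give an actual number in a functional assay on HT-29 cells (Homo sapiens) for cytotoxicity, read by sulforhodamine B assay, with a stated time of 72 h (a higher number here means a weaker inhibitor, a lower number a stronger inhibitor), where compound 1 gives 4100 nM. Compound 2 `CCCCC/C=C\C[C@@]1(O)C=C(I)C(=O)/C1=C\C=C\CCCC(=O)OC` reaches only a limit, > 10000 nM. Compound 3 `CCCCC/C=C\C[C@]1(OC(C)=O)C=CC(=O)/C1=C/C=C/CCCC(=O)OC` likewise reaches only a limit, > 10000 nM. Among the compounds with values here, the single step between compounds differing in one place, an at least 2.4-fold higher number from compound 1 to compound 3 (0.38 log units; beyond the scatter), ends at the limit of > 10000 nM in this assay, at which 2 of the 3 values shown sit. Compound 4 `CCCCC/C=C\C[C@]1(O)C=CC(=O)/C1=C\C=C\CCCC(=O)OC` differs from compound 1 in this way: the two compounds have the same atoms and bonds and differ only in configuration as drawn: 1 of 4 stereo elements differ; a double bond is drawn E in compound 1 and Z in compound 4. Within the data shown here, no measured step alters the geometry of a double bond, so that step offers no direct guide here. Compound 4 is expected to give 6000 nM in this assay, somewhere from 2000 nM to 20000 nM, with a fair chance of only a limit. The estimated step is a 1.5-fold higher number from compound 1 to compound 4 (0.17 log units; within the scatter).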

Compound 4, half-maximal inhibitory concentration: 7900 nM
Compound 4: middle estimate off by 1.3-fold (0.12 log units), on the low side; the measured number falls inside the stated range.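

Turning this one double bond from E to Z, with every atom and bond kept, gives a 1.9-fold higher number from compound 1 to compound 4 (0.28 log units; within the scatter) in this assay. The acetyl step lay beyond the scatter, whereas this geometry change does not, and compound 4 still reads as an actual number rather than a limit. Any reading of this step rests on one fact: the fact that compounds 1 and 4 differ only in the configuration as drawn.

As far as these compounds go, whether the double-bond geometry matters any more once acetyl sits on that oxygen stays open. So does what a free carboxylic acid in place of the methyl ester would give.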